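Changing the Ring on the Amine Nitrogen of Compound 1

A few compounds are considered here, and "the series" means these few. Any claim that something is new, unique, unknown or untested is made for them only; others in the source may bear on it.

compound 1 `Nc1ccccc1NC(=O)/C=C/c1ccc(Cn2cnc3c(NC4CCCCC4)nc(Cl)nc32)cc1`: 18.7%
compound 2 `CC1CCN(c2nc(Cl)nc3c2ncn3Cc2ccc(C(=O)Nc3ccccc3N)cc2)CC1`: 78.6%
compound 3 `CCCCn1cnc2c(Nc3cccc(Cl)c3)nc(NCOCc3ccc(C(=O)Nc4ccccc4N)cc3)nc21`: 71.9%

All three were tested in a functional assay on HCT-116 cells (Homo sapiens) for antiproliferative activity, read by CCK-8 assay, with a stated time of 72 h, tested at 8 uM; on this read-out higher numbers stand for a stronger effect at the one concentration tested and lower numbers for a weaker effect. Among them compound 1 stands lowest: compound 3 lies well above it, beyond the scatter, and compound 2 lies furthest above it, also beyond the scatter. Compounds 2 and 3 differ from compound 1 in several places at once, so no single change can be read off from their numbers.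

The compound not yet measured, compound 4 `Nc1ccccc1NC(=O)/C=C/c1ccc(Cn2cnc3c(Nc4cccc(OC(F)(F)F)c4)nc(Cl)nc32)cc1`, differs from compound 1 in one place: 3-(trifluoromethoxy)phenyl in place of cyclohexyl on a nitrogen on an aromatic ring. A six-membered non-aromatic ring of carbon only gives way to a six-membered aromatic ring that brings one hydrogen-bond acceptor. For the measured compounds named here, no measured pair shows this change on its own, so the size of the step is open. In this assay compound 4 is expected to come out higher than compound 1 by a number 26.3 percentage points higher from compound 1 to compound 4 (beyond the scatter), a step expected to be beyond the scatter, though with wide uncertainty. The estimate for compound 4 is 45%, with a range from 15% to 78%.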

Compound 4, a percentage reported as inhibition, at one concentration (the size of the read-out at that concentration, not a potency): 5.23%
Beside the measured number, compound 4's estimate is 39.8 percentage points above it, outside the stated range (below it).
By their numbers in this assay, from the lowest: compound 4; then compound 1; then compounds 3 and 2 (each within the scatter of the next).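

For the compounds shown here, this is the first change in the set that can be read on its own. In this assay, putting 3-(trifluoromethoxy)phenyl in place of cyclohexyl on the amine nitrogen gives a modest drop, a number 13.5 percentage points lower from compound 1 to compound 4 (beyond the scatter), so at this position the aromatic ring with its larger substituent does not lift the inhibition of a compound that was already weak. Nothing at hand explains the drop.

The step swaps the ring and adds the trifluoromethoxy group at once, so the compounds shown cannot say which of the two matters. A plain phenyl ring on the same nitrogen would separate the two, while a cyclopentyl ring would show how far the read-out follows the size of a non-aromatic ring.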